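A few compounds are considered here, and "the series" means these few. Any claim that something is new, unique, unknown or untested is made for them only; others in the source may bear on it.

Compound 1 `O=C(Nc1ccccc1)c1cnc(NCc2c(F)ccc3c2CCO3)n2cnnc12` was examined in a physicochemical assay for solubility, read by LC-MS, in phosphate buffer, with a stated time of 24 h, at pH 7.4; a lower number here means a less soluble compound, a higher number a more soluble compound. In this assay compound 1 gives only a limit, < 1000 nM, so its exact solubility is not known. Compound 2 `CNC(=O)c1cc(-c2cnc(NCc3c(F)ccc4c3CCO4)c3cn[nH]c(=O)c23)n(C)n1`, the other measured member of the set, gives 7000 nM in this assay. Of where compound 1 stands it can be said only that it sits at the limit of < 1000 nM in this assay, at which 1 of the 2 values shown sits. Compound 3 `CN(c1cccnc1)c1cnc(NCc2c(F)ccc3c2CCO3)n2cnnc12` has not yet been measured. It differs from compound 1 in one place: methyl(pyridin-3-yl)amino in place of phenylcarbamoyl on an aromatic carbon. Within the data shown here, no step between measured compounds is recorded to show the size of such a change, and the measured values of compound 1 and compound 2 offer no pair that isolates it. The step of an at least 2.0-fold higher number from compound 1 to compound 3 (0.30 log units; that floor lies within the scatter) is expected to be a modest rise in this assay, though a result that again reports only a limit would not be surprising. For compound 3 the expected solubility is 2000 nM, within a range of 500 nM to 8000 nM.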

Compound 3, solubility: 47000 nM
The estimate for compound 3 lay 24-fold (1.37 log units) below the measured number; measured number above the stated range.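

Swapping phenylcarbamoyl for methyl(pyridin-3-yl)amino on this aromatic carbon, para to a large group, gives an at least 47-fold higher number from compound 1 to compound 3 (1.67 log units; beyond the scatter) in this assay. Among these compounds, this is the first measured step at this position, and it shows that a single exchange here, with the rest of the core of compound 1 unchanged, can go with a large rise in the read-out. The value of compound 1 is only a limit, so the step gives a floor and not an exact size: the limit of < 1000 nM in this assay, at which 1 of the 3 values shown sits.

The exchange alters several things at once, so the compounds shown do not separate the ring nitrogen, the methyl and the loss of the carbonyl link. On these data alone, a methyl(phenyl)amino group or a pyridin-3-ylamino group at the same carbon would bear on this, and how far the step carries to other cores also remains open.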